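Carbamate replaces amide-linked propyl ether in pancreatic cell series

The source may report more compounds than this note shows. Statements on the series, on what has been measured and on what is new or still open speak of the compounds shown alone.

Compound 2 `CC(C)=CCC/C(C)=C/CC1Cc2c(OCCCNC(=O)c3cccs3)cc(=O)n(CCCO)c2CC1(C)C` gives 11.5% in a functional assay on PANC-1 cells (Homo sapiens) for inhibition, read by MTT assay, with a stated time of 24 h, tested at 10 uM; a lower number here means less inhibition, a higher number more inhibition at the concentration tested (going by the name of the read-out); it stands highest of the two numbers recorded, with compound 1 `CC(C)=CCC/C(C)=C/CC1Cc2c(OCCCNC(=O)c3ccco3)cc(=O)n(CCCO)c2CC1(C)C` nearest at 2.8%, though the step of a number 8.7 percentage points higher from compound 1 to compound 2 (within the scatter) lies within the scatter. Compound 3 `COc1ccc(NC(=O)Oc2cc(=O)n(CCCO)c3c2CC(C/C=C(\C)CCC=C(C)C)C(C)(C)C3)cc1` has not yet been measured. Its change from compound 2 is (4-methoxyphenyl)carbamoyl in place of 3-(((thiophen-2-yl)carbonyl)amino)propyl on an oxygen on an aromatic ring. Within the data shown here, the one measured step, a number 8.7 percentage points higher from compound 1 to compound 2 (within the scatter), concerns a carbonyl carbon and not the oxygen on the aromatic ring altered here, so it bears on this step only in showing that exchanging one five-membered aromatic ring for another left the read-out within the scatter. Among the measured compounds shown here, no measured step touches the oxygen on the aromatic ring. With both recorded values small, compound 3 is expected to remain near them, and a number 1.5 percentage points lower from compound 2 to compound 3 (within the scatter) is estimated as no step beyond the scatter. The estimate for compound 3 is 10%, within 0% to 30%.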

Compound 3, a percentage reported as inhibition, at one concentration (the size of the read-out at that concentration, not a potency): 0%
Estimate against measurement, compound 3: 10 percentage points above; low and high end bracket the measured number.
By their numbers in this assay, from the lowest: compounds 3, 1 and 2 (each within the scatter of the next, the first and the last beyond it).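

At the oxygen on an aromatic ring, this assay shows a number 11.5 percentage points lower from compound 2 to compound 3 (beyond the scatter), while the corresponding exchange from the furan-2-yl member gives a number 2.8 percentage points lower from compound 1 to compound 3 (within the scatter). This change of (4-methoxyphenyl)carbamoyl for the amide-bearing propyl group, at equal heavy-atom, donor and acceptor counts, therefore separates compound 3 from the thiophen-2-yl member only, and that modest separation rests on a single pair. Nothing available bears on the reason for this step.

Both the linking atoms and the aromatic ring change together in compound 3, so the compounds shown leave open which part accounts for the step. Also open, going by these compounds, is how the read-out responds when this oxygen carries a simple 3-aminopropyl group or a chain ending in a carboxylic acid.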